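From Ethyl to Methyl at the Clearance Limit

The source may hold more compounds than are shown below. What is called first, only, known or untested is meant among the compounds shown, and "the series" means these compounds.

Of the compounds shown here, three have been read in an ADME assay on microsomes from liver (Homo sapiens) for metabolic stability, read by LC-MS, using NADPH, with stated times of 10 min and 30 min (on this read-out higher numbers stand for fast clearance and lower numbers for slow clearance), and none of them gives a number. Compound 1 (`CC(=O)N[C@@H]1CCCc2c1cncc2N1C(=O)c2ccc(Cl)cc2[C@@H]1C`) reads < 3.5 mL/min/kg, which is a limit of the assay. Compound 2 (`CC[C@@H]1c2cc(Cl)ccc2C(=O)N1c1cncc2c1CCC[C@H]2NC(C)=O`) reads < 3.5 mL/min/kg, also a limit. Compound 3 (`CC1(C)c2cc(Cl)ccc2C(=O)N1c1cccnc1`) reads < 3.5 mL/min/kg, again a limit. Compound 2 therefore has no number of its own and shares its place with the other two, as the limit of < 3.5 mL/min/kg in this assay, at which 3 of the 3 values shown sit, shows.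

Compound 4 (`CC(=O)N[C@@H]1CCCc2c1cncc2N1C(=O)c2ccc(Cl)cc2[C@H]1C`) has not yet been measured. It differs from compound 2 by hydrogen in place of methyl on a saturated chain carbon bound to a saturated ring carbon, with hydrogen in place of methyl on a saturated chain carbon bound to a saturated ring carbon, which also reads as ethyl to methyl. Within the data shown here, no measured pair shows this change in this assay, so no step beyond the usual scatter is expected, in either direction. That expectation rests on compound 2, whose < 3.5 mL/min/kg is a limit. The estimated change is a step that the limit leaves unreadable from compound 2 to compound 4. For compound 4 the expected clearance is 3 mL/min/kg, within an estimated range of 1.5 mL/min/kg to 6 mL/min/kg.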

Compound 4, clearance: < 3.5 mL/min/kg
Compound 4: no number, only a limit (the forecaster's own chance of this, stated with the estimate: 75%); the middle value is on the limit's open side.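

Compound 4 gives < 3.5 mL/min/kg in this assay, which is a limit of the assay. The steps to compound 4 from compound 1 and compound 2 cannot be read. The compounds shown leave open how far ethyl to methyl, or the configuration as drawn, shifts clearance.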